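Bromo series: pyrrolidin-1-yl to piperidin-1-yl

This account rests on a few compounds, and the source may have more. Where it says the series, first, only, none or still open, it means among the compounds named here.

Compound 1 `O=C(c1ccccc1)c1sc(N2CCCC2)nc1Cl`: 44000 nM
Compound 2 `O=C(c1ccccc1)c1sc(N2CCCC2)nc1Br`: > 100000 nM (a limit)
Compound 3 `N#Cc1sc(N2CCCC2)nc1Cl`: > 100000 nM (a limit)

In a functional assay on Hs 683 cells (Homo sapiens) for cytotoxicity, read by MTT assay, with a stated time of 72 h (a lower number here means a stronger inhibitor, a higher number a weaker inhibitor), compound 2 stands at the limit of > 100000 nM in this assay, at which 2 of the 3 values shown sit, so it offers a limit and no number. Compound 4 `O=C(c1ccccc1)c1sc(N2CCCCC2)nc1Br` differs from compound 2 in one place: piperidin-1-yl in place of pyrrolidin-1-yl on an aromatic carbon. Among the compounds with values here, the only measured step is an at least 2.2-fold higher number from compound 1 to compound 2 (0.35 log units; beyond the scatter), a halogen exchange that leaves the pyrrolidin-1-yl untouched. Within the data shown here, it bears on the question only indirectly, by showing where the bromo compound sits, and no measured step covers the exchange of pyrrolidin-1-yl for piperidin-1-yl. No step beyond the scatter is therefore expected in this assay, with no direction favoured. This expectation rests on compound 2 at > 100000 nM, which is a limit. Compound 4 may well report only a limit too. For compound 4 the expected value is 90000 nM, with an estimated range of 35000 nM to 150000 nM. This estimate means an at least 1.1-fold lower number from compound 2 to compound 4 (0.04 log units; that floor lies within the scatter).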

Compound 4, half-maximal inhibitory concentration: 38000 nM
For compound 4 the middle estimate is 2.4-fold (0.37 log units) above the measured one, within the range that was stated.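

In this assay, within the data shown here, the only earlier step changed the halogen and left pyrrolidin-1-yl in place, whereas this one shows that the group on the aromatic carbon next to the ring nitrogen and the ring sulfur also matters: an at least 2.6-fold lower number from compound 2 to compound 4 (0.42 log units; beyond the scatter). Compound 4 gives 38000 nM, so a bromo group on the shared core does not by itself rule out a measured number. The true size of the step remains unknown because compound 2 offers only a limit: the limit of > 100000 nM in this assay, at which 2 of the 4 values shown sit.

From the compounds shown here alone, whether piperidin-1-yl in place of pyrrolidin-1-yl has a similar effect alongside chloro remains open. Also open, going by these compounds, is how a morpholin-4-yl ring, a seven-membered azepan-1-yl ring or an open-chain dimethylamino group would behave at this position.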